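The source may report more compounds than this note shows. Statements on the series, on what has been measured and on what is new or still open speak of the compounds shown alone.

Compound 1 `COc1cc(-c2cc(/C=C/C(=O)c3ccc(N)cc3)[nH]n2)cc(OC)c1OC`, compound 2 `COc1ccc(C(=O)/C=C/c2cc(-c3cc(OC)c(OC)c(OC)c3)n[nH]2)cc1OC` and compound 3 `COc1cc(-c2cc(/C=C/C(=O)c3ccc(F)c(F)c3)[nH]n2)cc(OC)c1OC` share one core and differ only in the aryl group on the carbonyl carbon. In a functional assay on NCI/ADR-RES cells (Homo sapiens) for cytotoxicity, read by sulforhodamine B assay, with a stated time of 48 h, tested at 1 uM (on this read-out higher numbers stand for a weaker effect at the one concentration tested and lower numbers for a stronger effect), compound 1 gives 98%, compound 2 gives 90% and compound 3 gives 95%. Compound 2 holds the lowest of the three numbers, but both gaps stay within the scatter: a number 8 percentage points lower from compound 1 to compound 2 (within the scatter) and a number 5 percentage points higher from compound 2 to compound 3 (within the scatter). Compound 4 `COc1cc(C(=O)/C=C/c2cc(-c3cc(OC)c(OC)c(OC)c3)n[nH]2)cc(OC)c1OC` differs from compound 2 by methoxy in place of hydrogen on an aromatic carbon. Within the data shown here, no measured step adds a group to this ring; the swaps of the whole aryl group on the carbonyl carbon all stayed within the scatter, so no change beyond the scatter is expected in this assay. Compound 4 is estimated at 92% (range 78% to 102%). The implied step, a number 2 percentage points higher from compound 2 to compound 4 (within the scatter), is expected to lie within the scatter.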

Compound 4, a percentage reported as activity, at one concentration (the size of the read-out at that concentration, not a potency): 95%
Compound 4: middle estimate off by 3 percentage points, on the low side, within the range that was stated.
By their numbers in this assay, from the lowest: compounds 2, 3, 4 and 1 (each within the scatter of the next).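

In this assay, methoxy in place of hydrogen on an aromatic carbon gives a number 5 percentage points higher from compound 2 to compound 4 (within the scatter). Among these compounds, this is the first measured change that adds a group to this ring rather than swapping the whole aryl group, and like those swaps it stays within the scatter. No evidence bears on this result. On these data alone, whether a hydroxy group or a carboxylic acid at this position, or a longer chain in place of methoxy, would move the read-out beyond the scatter remains open. A read-out at one concentration also leaves open how the effects of compound 2 and compound 4 compare at any other concentration.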